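The source may hold more compounds than are shown below. What is called first, only, known or untested is meant among the compounds shown, and "the series" means these compounds.

Three compounds have been measured in a functional assay on the whole organism (Ehrlich cells) with Mus musculus as the target, at a dose of 50 mg/kg by the intraperitoneal route; a higher number here means more inhibition at the dose given (going by the name of the read-out), a lower number less inhibition:

compound 1 `Cc1ccc(S(=O)(=O)N2C(=O)CCC2C(=O)NN)cc1` gives 50.1%
compound 2 `Cc1ccc(S(=O)(=O)N2C(=O)CCC2C(=O)NNc2ccccc2)cc1` gives 77.6%
compound 3 `O=C(NNc1ccccc1)C1CCC(=O)N1S(=O)(=O)c1ccc(Cl)c(Cl)c1` gives 66.9%

Compound 4 `NNC(=O)C1CCC(=O)N1S(=O)(=O)c1ccc(Cl)c(Cl)c1` has not yet been measured. It differs from compound 3 in one place: hydrogen in place of phenyl on an amine nitrogen. The same change has already been made once among the measured compounds, from compound 2 to compound 1, where it gave a number 27.5 percentage points lower from compound 2 to compound 1 (beyond the scatter). The cores of compound 2 and compound 3 differ in turn by 3,4-dichlorophenyl in place of 4-methylphenyl on a sulfonyl sulfur, a change that gave a number 10.7 percentage points lower from compound 2 to compound 3 (beyond the scatter). Since the place of the change is the same in both pairs, a similar step is expected here: from compound 3 the estimate is a number 26.9 percentage points lower from compound 3 to compound 4 (beyond the scatter), resting on the step of a number 27.5 percentage points lower from compound 2 to compound 1 (beyond the scatter) seen with the same change. Compound 4 is therefore estimated at 40%, with a range from 26% to 54%.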

Compound 4, a percentage reported as inhibition, in the whole organism at one dose (the size of the read-out at that dose, not a potency): 59.3%
Compound 4: the middle estimate sits 19.3 percentage points below what was measured; the whole stated range lies below it.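

In this assay, hydrogen in place of phenyl on an amine nitrogen now gives a number 7.6 percentage points lower from compound 3 to compound 4 (within the scatter). The size of the step therefore did not carry over from one core to the other, so the earlier step was a poor guide to this one: the same change on two cores in this assay, a number 27.5 percentage points lower (beyond the scatter) from compound 2 to compound 1 and a number 7.6 percentage points lower (within the scatter) from compound 3 to compound 4, 19.9 percentage points apart, beyond the scatter of two such steps This shows that, in these two pairs, the outcome of the change depends on whether 4-methylphenyl or 3,4-dichlorophenyl stands on the sulfonyl sulfur, but it does not show why, and two pairs give no rule for any further core.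

The compounds shown leave open how a methyl or benzyl group on the same amine nitrogen would compare with phenyl and hydrogen. They also leave open which size of step a 4-chlorophenyl group on the sulfonyl sulfur would follow.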